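The source may hold more compounds than are shown below. What is called first, only, known or untested is meant among the compounds shown, and "the series" means these compounds.

Working notes on the series

Compound 2 `CC(=O)Nc1cccc(C(=O)N2CCCC(C(=O)Nc3ccc(Cl)cc3)C2)c1` is the reference for the next step. Among the measured compounds shown here, in an ADME assay on PC-3 cells (Homo sapiens) for cytotoxicity, read by WST assay, tested at 100 uM (on this read-out lower numbers stand for less inhibition and higher numbers for more inhibition at the one concentration tested (going by the name of the read-out)), compound 2 gives 4%, and its only neighbour, compound 1 `COC(=O)c1cccc(C(=O)N2CCCC(C(=O)Nc3ccc(Cl)cc3)C2)c1`, gives 0% in this assay. The two numbers lie within the scatter of each other, so compound 2 stands with compound 1 at the low end of the read-out and nothing separates them; the step of a number 4 percentage points higher from compound 1 to compound 2 (within the scatter) records this.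

Compound 3 `O=C(Nc1ccc(Cl)cc1)C1CCCN(C(=O)c2cccc(-c3cccs3)c2)C1` is not yet measured. It differs from compound 2 in one place: thiophen-2-yl in place of acetamido on an aromatic carbon. For the measured compounds named here, the only measured step that bears on this, the change from compound 1 to compound 2 at the same aromatic carbon, was a number 4 percentage points higher from compound 1 to compound 2 (within the scatter) and did not leave the scatter. Going by the values given here, both measured compounds sit near the bottom of the read-out, and no step has yet moved the number beyond the scatter, so the step to compound 3 is expected to be a number 2 percentage points higher from compound 2 to compound 3 (within the scatter), with no direction claimed. Compound 3 is therefore estimated at 6% in this assay, within a range of 0% to 25%.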

Compound 3, a percentage reported as inhibition, at one concentration (the size of the read-out at that concentration, not a potency): 4%
For compound 3 the middle estimate is 2 percentage points above the measured one, and the stated range covers the measured number.
By their numbers in this assay, from the lowest: compounds 1, 2 and 3 (each within the scatter of the next).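

The position on the aromatic carbon, meta to a large group, now carries a ring: in this assay, thiophen-2-yl, with one five-membered aromatic ring and 0 hydrogen-bond donors, in place of acetamido, with no ring and 1 hydrogen-bond donor, gives no change at the digits printed from compound 2 to compound 3 (within the scatter). Set against methoxycarbonyl, the same ring gives a number 4 percentage points higher from compound 1 to compound 3 (within the scatter), so the three groups at this carbon, only one of which brings a ring, all lie within the scatter of one another and the read-out stays near the bottom for each. No measurement on hand bears on why these groups read alike, and the result can be taken only as a description of the numbers.

Open, as far as these compounds go, is whether any group at this carbon can move the number beyond the scatter, for instance an amine, a carboxylic acid or a longer chain in place of thiophen-2-yl. The rest of the core is the same in all three compounds, so these numbers say nothing about a change anywhere else on it.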